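Changing the end ring of compound 2

The source may hold more compounds than are shown below. What is called first, only, known or untested is meant among the compounds shown, and "the series" means these compounds.

Compound 1 `FC(F)(F)c1ccc(-c2ccc(-c3ccc(-c4nc5ccccc5[nH]4)cc3)cc2)cc1` gives 100000 nM
Compound 2 `Oc1cccc2[nH]c(-c3ccc(-c4ccc(-c5ccc(C(F)(F)F)cc5)cc4)cc3)nc12` gives 3720 nM

Within the data shown here, in a functional assay on SiHa cells (Homo sapiens) for inhibition, read by sulforhodamine B assay (on this read-out lower numbers stand for stronger inhibition of growth and higher numbers for weaker inhibition of growth), compound 2 gives 3720 nM and holds the lower of the two numbers so far. Among the measured compounds shown here, the only measured step is a 27-fold lower number from compound 1 to compound 2 (1.43 log units; beyond the scatter) and it is large, but it comes from hydroxy in place of hydrogen, a different change. For the measured compounds named here, compound 3 `Oc1cccc2[nH]c(-c3ccc(-c4ccc(-c5cccc(Cl)c5)cc4)cc3)nc12` differs from compound 2 by 3-chlorophenyl in place of 4-(trifluoromethyl)phenyl on an aromatic carbon and no measured step covers that swap. With no evidence for a shift, no step beyond the scatter is expected, in either direction. The estimated step is a 1.2-fold lower number from compound 2 to compound 3 (0.09 log units; within the scatter) on this thin evidence. Compound 3 is expected at 3000 nM with an estimated range of 900 nM to 11000 nM for now.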

Compound 3, concentration for 50% growth inhibition: 8400 nM
Estimate against measurement, compound 3: 2.8-fold (0.45 log units) below, and the stated range covers the measured number.
By their numbers in this assay, from the lowest: compound 2; then compound 3; then compound 1.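

The end ring is not a neutral spot: 3-chlorophenyl in place of 4-(trifluoromethyl)phenyl gives a 2.3-fold higher number from compound 2 to compound 3 (0.35 log units; beyond the scatter) and so weaker inhibition of growth. The earlier compounds shown here showed only the effect of the hydroxy on the core, whereas this modest step shows that the far end of the molecule also changes the result. Nothing measured here accounts for the shift.

This swap changes both the ring's substituent and its printed position, and the two effects remain tangled. Also open, going by these compounds, is how 4-chlorophenyl or an end ring carrying an amine or a carboxylic acid would compare with compound 2.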